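This account rests on a few compounds, and the source may have more. Where it says the series, first, only, none or still open, it means among the compounds named here.

Measured compounds:
- compound 1, `Nc1scc(CN2CCN(c3ccc(Cl)cc3Cl)CC2)c1C(=O)c1ccc(Cl)cc1`, -11%
- compound 2, `Nc1scc(CN2CCN(c3cc(Cl)cc(Cl)c3)CC2)c1C(=O)c1ccc(Cl)cc1`, -22%
- compound 3, `Nc1scc(CN2CCN(C3CCCCCC3)CC2)c1C(=O)c1ccc(Cl)cc1`, 13%

All three share a common core and differ only in the group attached to an amine nitrogen in a ring. In a functional assay on CHO cells with adenosine receptor A1 (Homo sapiens) as the target, read by cAMP accumulation and immunoassay, with a stated time of 6 min, tested at 0.1 uM (a lower number here means a stronger effect, a higher number a weaker effect of the compound at the concentration tested), compound 3 gives 13%, the highest of the three numbers; the steps of a number 24 percentage points higher from compound 1 to compound 3 (beyond the scatter) and a number 35 percentage points higher from compound 2 to compound 3 (beyond the scatter) are both beyond the scatter, so compound 3 shows the weakest effect at the tested concentration.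

Compound 4, `Nc1scc(CN2CCN(c3c(F)cc(F)cc3F)CC2)c1C(=O)c1ccc(Cl)cc1`, has not yet been measured in this assay. It differs from compound 3 in one place: 2,4,6-trifluorophenyl in place of cycloheptyl on an amine nitrogen in a ring.

The two steps that bear on this change both move from a dichlorophenyl group to cycloheptyl on that nitrogen and both raise the number: a number 24 percentage points higher from compound 1 to compound 3 (beyond the scatter) and a number 35 percentage points higher from compound 2 to compound 3 (beyond the scatter). Going by the values given here, compound 4 goes the other way, from cycloheptyl back to a substituted phenyl, so a step downward of roughly that size is expected, though no measured compound carries a trifluorophenyl group, and the fluorine pattern differs from either dichloro pattern seen.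

The expected step is a number 25 percentage points lower from compound 3 to compound 4 (beyond the scatter). Compound 4 is therefore estimated at -12%, with a range from -35% to 12%.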

Compound 4, a percentage reported as activity, at one concentration (the size of the read-out at that concentration, not a potency): -3.9%
Compound 4: middle estimate off by 8.1 percentage points, on the low side, within the range that was stated.
By their numbers in this assay, from the lowest: compound 2; then compounds 1 and 4 (each within the scatter of the next); then compound 3.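

In this assay, 2,4,6-trifluorophenyl on this amine nitrogen again gives a lower number than cycloheptyl (a number 16.9 percentage points lower from compound 3 to compound 4 (beyond the scatter)), so the shift seen with the two dichlorophenyl groups also appears with a ring carrying fluorine instead of chlorine. The halogenated phenyl groups do not all behave alike, however: the 3,5-dichlorophenyl group stays apart from the new group (a number 18.1 percentage points higher from compound 2 to compound 4 (beyond the scatter)), whereas the 2,4-dichlorophenyl group cannot be told apart from it (a number 7.1 percentage points higher from compound 1 to compound 4 (within the scatter)). Both the halogen and its pattern on the ring change together in these steps, so the compounds cannot show which of the two accounts for the gap between compound 2 and compound 4.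

A plain phenyl group with no halogen would help separate the effect of the aromatic ring from that of its halogens, and a cyclohexyl group would show how much the size of the saturated ring matters. Nothing measured alongside these values explains why the groups differ.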